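Cyano for fluoro on the piperazine aryl group

A few compounds are considered here, and "the series" means these few. Any claim that something is new, unique, unknown or untested is made for them only; others in the source may bear on it.

Three compounds of the shared core have numbers in a functional assay on HeLa cells (Homo sapiens) for antiproliferative activity, read by CCK-8 assay, with a stated time of 72 h, tested at 8 uM; a higher number here means a stronger effect of the compound at the concentration tested, a lower number a weaker effect. Compound 1 `Nc1ccccc1NC(=O)c1ccc(CSC(=S)N2CCN(C3CCCCC3)CC2)cc1` gives 76.1%. Compound 2 `Nc1ccccc1NC(=O)c1ccc(CSC(=S)N2CCN(C(c3ccccc3)c3ccccc3)CC2)cc1` gives 13.8%. Among the measured compounds shown here, compound 3 `Nc1ccccc1NC(=O)c1ccc(CSC(=S)N2CCN(c3ccc(F)cc3)CC2)cc1` gives 64.5%, the second highest of the three; the one measured step leading to it, a number 11.6 percentage points lower from compound 1 to compound 3 (beyond the scatter), is modest but beyond the scatter. Compound 4 `N#Cc1ccc(N2CCN(C(=S)SCc3ccc(C(=O)Nc4ccccc4N)cc3)CC2)cc1` differs from compound 3 by cyano in place of fluoro on an aromatic carbon. For the measured compounds named here, no measured step exchanges one substituent on that aromatic ring for another; the one measured step concerns the group on the amine nitrogen itself, and compound 2 shows only how far a different group there can move the number. The step to compound 4 is therefore expected to be small, a number 4.5 percentage points lower from compound 3 to compound 4 (within the scatter), in no sure direction. Compound 4 is estimated at 60%, with a range from 40% to 78%.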

Compound 4, a percentage reported as inhibition, at one concentration (the size of the read-out at that concentration, not a potency): 70.6%
Estimate against measurement, compound 4: 10.6 percentage points below, and the stated range covers the measured number.
By their numbers in this assay, from the lowest: compound 2; then compounds 3, 4 and 1 (each within the scatter of the next, the first and the last beyond it).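

In this assay, among the compounds shown here, the first exchange of one substituent on this aromatic ring gives a number 6.1 percentage points higher from compound 3 to compound 4 (within the scatter), so 4-cyanophenyl and 4-fluorophenyl cannot be told apart here. With 4-cyanophenyl on the amine nitrogen in the ring, the comparison with cyclohexyl gives a number 5.5 percentage points lower from compound 1 to compound 4 (within the scatter), so these two groups cannot be told apart here either. No measured evidence bears on either step.

Going by these compounds, whether an amine, a carboxylic acid or a methoxy group on this aromatic carbon would fall in the same range remains open. Readings at one concentration also leave the potency of compound 3 and compound 4 open.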